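A few compounds are considered here, and "the series" means these few. Any claim that something is new, unique, unknown or untested is made for them only; others in the source may bear on it.

Measured compounds:
Compound 1, `CC[C@@H]1C(=O)N(C)c2cnc(-n3ccnc3-c3ccc(F)cc3)nc2N1[C@H]1CCOC1`: 63%
Compound 2, `CC(C)N1c2nc(-n3ccnc3-c3ccc(F)cc3)ncc2N(C)C(=O)C1(C)C`: 25%
Compound 3, `CC[C@@H]1C(=O)N(C)c2cnc(-n3ccnc3-c3ccccc3)nc2N1[C@H]1CCOC1`: 51%

In an ADME assay on microsomes from liver (Mus musculus) for metabolic stability, with a stated time of 30 min, tested at 1 uM (on this read-out higher numbers stand for a more stable compound and lower numbers for a less stable compound), compound 1 holds the highest of the three numbers. The nearest number is that of compound 3, and the step between them is a number 12 percentage points lower from compound 1 to compound 3 (beyond the scatter), beyond the scatter. Compound 2 lies furthest away, well below compound 1, with no single-point comparison to it.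

Compound 4, `CC[C@@H]1C(=O)N(C)c2cnc(-n3ccnc3-c3ccc(F)cc3)nc2N1C1COC1`, differs from compound 1 by oxetan-3-yl in place of oxolan-3-yl on a nitrogen on an aromatic ring in a ring. Among the measured compounds shown here, no measured step bears on this position: the one step in hand concerns hydrogen in place of fluoro on an aromatic carbon, and compound 2 differs from compound 1 in several places at once. With nothing to fix a direction, the estimate for compound 4 is a step of a number 5 percentage points lower from compound 1 to compound 4 (within the scatter), and the range is kept wide. Compound 4 is therefore expected at 58%, between 38% and 76%.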

Compound 4, percent of the compound remaining: 74%
Beside the measured number, compound 4's estimate is 16 percentage points below it; the range from low to high includes it.
By their numbers in this assay, from the lowest: compound 2; then compound 3; then compound 1; then compound 4.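

In this assay, oxetan-3-yl in place of oxolan-3-yl gives a number 11 percentage points higher from compound 1 to compound 4 (beyond the scatter), the first step read at this position, so the read-out responds to the group here and the four-membered ring is tolerated. The change also removes the defined stereocentre of the oxolan-3-yl group, and this one step cannot separate that loss from ring size. No measured evidence accounts for the step.

Going by these compounds, whether the step holds with hydrogen in place of fluoro, as in compound 3, stays open. So does the reading of cyclobutyl or an amine-bearing ring at this position.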